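Piperidin-1-yl in Place of Pyrrolidin-1-yl on Compound 1

This account rests on a few compounds, and the source may have more. Where it says the series, first, only, none or still open, it means among the compounds named here.

In an ADME assay on L6 cells (Rattus norvegicus) for cytotoxicity, read by fluorescence, with a stated time of 72 h (a lower number here means a stronger inhibitor, a higher number a weaker inhibitor), compound 1 `CN1CCN(C23CC(NC(=O)CCN4CCCC4)C(C(c4ccccc4)C2)C(c2ccccc2)C3)CC1` gives 42200 nM. Going by the values given here, only one other number is available for comparison: compound 2 `CN1CCN(C23CC(NCCC(=O)N4CCCC4)C(C(c4ccccc4)C2)C(c2ccccc2)C3)CC1` gives 21500 nM, and the two values lie within the scatter of each other. Compound 3 `CN1CCN(C23CC(NC(=O)CCN4CCCCC4)C(C(c4ccccc4)C2)C(c2ccccc2)C3)CC1` has not yet been measured. It differs from compound 1 by one change, (piperidin-1-yl in place of pyrrolidin-1-yl on a saturated chain carbon, two bonds along the chain from a carbonyl carbon), with piperidin-1-yl in place of pyrrolidin-1-yl on a saturated chain carbon, two bonds along the chain from a carbonyl carbon.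

Among the compounds with values here, the single measured step, a 2.0-fold lower number from compound 1 to compound 2 (0.29 log units; within the scatter), bears on this only indirectly. It places 2-((pyrrolidin-1-yl)carbonyl)ethyl in place of (2-(pyrrolidin-1-yl)ethyl)carbonyl on an amine nitrogen and leaves the pyrrolidin-1-yl group in place. Within the data shown here, no measured pair shows the exchange of pyrrolidin-1-yl for piperidin-1-yl, so the data give no direct guide to it. The one structural rearrangement that was measured stayed within the scatter, so no step beyond the scatter is expected in this assay. The expected change is a 1.3-fold lower number from compound 1 to compound 3 (0.11 log units; within the scatter). For compound 3 the estimated value is 33000 nM, with an expected range from 14000 nM to 75000 nM.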

Compound 3, half-maximal inhibitory concentration: 15400 nM
Compound 3: the middle estimate sits 2.1-fold (0.33 log units) above what was measured; the measured number falls inside the stated range.
By their numbers in this assay, from the lowest: compounds 3, 2 and 1 (each within the scatter of the next, the first and the last beyond it).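

In this assay, piperidin-1-yl in place of pyrrolidin-1-yl on a saturated chain carbon, two bonds along the chain from a carbonyl carbon, gives a 2.7-fold lower number from compound 1 to compound 3 (0.44 log units; beyond the scatter). This is the first step among these compounds that passes the scatter, if only modestly, and it shows that the number responds to the ring at the end of this chain, a response the rearrangement linking the first two compounds did not show. The ring exchange does not, however, set compound 3 apart from the other rearranged compound, since the step is a 1.4-fold lower number from compound 2 to compound 3 (0.14 log units; within the scatter), so the three compounds do not form a clear order. Nothing available explains why the six-membered ring gives this result.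

As far as these compounds go, it remains open whether the number would shift further with azepan-1-yl, morpholin-4-yl or an open dimethylamino group at the same place, or with a longer chain leading to the piperidin-1-yl ring. It is also unknown whether piperidin-1-yl would produce a similar step on the 2-((pyrrolidin-1-yl)carbonyl)ethyl arrangement of compound 2.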